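From piperidin-3-yl to pyrrolidin-3-yl on the shared core

A few compounds are considered here, and "the series" means these few. Any claim that something is new, unique, unknown or untested is made for them only; others in the source may bear on it.

In a functional assay on Ramos cells (Homo sapiens) for cytotoxicity, read by CCK-8 assay, with a stated time of 72 h (on this read-out higher numbers stand for weaker inhibition and lower numbers for stronger inhibition), compound 1 `Cn1cc(NC(=O)c2cnc3ccc(N4CCC[C@@H](N)C4)nn23)c(C(F)F)n1` gives 44300 nM. Compound 2 `Cn1cc(NC(=O)c2cnc3ccc(N[C@H]4CCCNC4)nn23)c(C(F)F)n1` is reported only as > 50000 nM, which is a limit of the assay and not a number. As far as these compounds go, its exact position on the scale therefore stays unknown.

Compound 3 `Cn1cc(NC(=O)c2cnc3ccc(N[C@@H]4CCNC4)nn23)c(C(F)F)n1` keeps the core of compound 2 and alters only the ring on the amine: pyrrolidin-3-yl in place of piperidin-3-yl on a nitrogen on an aromatic ring. In words, this puts pyrrolidin-3-yl in place of piperidin-3-yl on a nitrogen on an aromatic ring.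

Within the data shown here, the only measured step is an at least 1.1-fold higher number from compound 1 to compound 2 (0.05 log units; that floor lies within the scatter). It exchanges 3-aminopiperidin-1-yl for (piperidin-3-yl)amino on an aromatic carbon, so it does not test a change of ring size. Among the measured compounds shown here, with that small floor as the sole guide, no step beyond the scatter is expected in this assay, and another report of a limit is quite likely. The expected size of the change is a number no higher from compound 2 to compound 3 (the limit leaves the size open). For compound 3 the estimated value is about 50000 nM, with an expected range of 20000 nM to 100000 nM.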

Compound 3, half-maximal inhibitory concentration: 45000 nM
Compound 3: middle estimate off by 1.1-fold (0.05 log units), on the high side; low and high end bracket the measured number.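

In this assay, the change from piperidin-3-yl to pyrrolidin-3-yl on a nitrogen on an aromatic ring gives an at least 1.1-fold lower number from compound 2 to compound 3 (0.04 log units; that floor lies within the scatter). This is the first look at ring size in this place, but compound 2 is reported only as a limit and not as a number, and that leaves just a floor for the step: the limit of > 50000 nM in this assay, at which 1 of the 3 values shown sits.

The firmer comparison is with compound 1, which carries 3-aminopiperidin-1-yl on the aromatic carbon: the exchange for (pyrrolidin-3-yl)amino gives a 1.0-fold higher number from compound 1 to compound 3 (0.01 log units; within the scatter). Compound 3 thus gives a real number where compound 2 gave only a limit, and none of the three compounds can be ranked above another in this assay.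

As far as these compounds go, neither step shows that the ring in this place changes the read-out beyond the scatter, so the true size of the step from the six-membered to the five-membered ring remains unknown. From the compounds shown here alone, whether a smaller azetidin-3-yl ring or an open 2-aminoethyl chain on the same nitrogen would move the number beyond the scatter stays open.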